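The source may hold more compounds than are shown below. What is called first, only, known or untested is meant among the compounds shown, and "the series" means these compounds.

Compound 1 `Cc1ncc([N+](=O)[O-])n1CC(=O)NS(=O)(=O)c1ccc(Cl)cc1`: 0.92 ug/mL in a functional assay on B16-F10 cells (Mus musculus) for antiproliferative activity, read by MTT assay, with a stated time of 48 h; a higher number here means a weaker inhibitor, a lower number a stronger inhibitor
Compound 2 `Cc1ncc([N+](=O)[O-])n1CC(=O)NS(=O)(=O)c1ccc(F)cc1`: 0.35 ug/mL
Compound 3 `O=C(Cc1ccc(F)cc1)NS(=O)(=O)c1ccc(F)cc1`: 4.23 ug/mL

Among these three, compound 2 gives the lowest number in this assay, so it is the strongest inhibitor shown. Compound 1 stands nearest to it, with a 2.6-fold lower number from compound 1 to compound 2 (0.42 log units; beyond the scatter) separating the two, a step that lies beyond the usual scatter. Within the data shown here, compound 3, which lacks the nitroimidazole part of the shared core, stands furthest away; no single-place step to it is given, and its value simply shows a much higher number than that of compound 2.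

Compound 4 `Cc1ncc([N+](=O)[O-])n1CC(=O)NS(=O)(=O)c1ccc(Br)cc1` is the next compound. Compared with compound 2 the change is bromo in place of fluoro on an aromatic carbon. Among the measured compounds shown here, only one measured step bears on it: the halogen swap at the same place, a 2.6-fold lower number from compound 1 to compound 2 (0.42 log units; beyond the scatter), where moving from chloro to fluoro lowered the number. The new change moves away from fluoro to another halogen, so the expected step is in the opposite direction and of roughly similar size, that is a moderately higher number. For compound 4 the estimate in this assay is 1.2 ug/mL, with a range from 0.4 ug/mL to 3.5 ug/mL, which means an expected step of a 3.4-fold higher number from compound 2 to compound 4 (0.54 log units; beyond the scatter).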

Compound 4, half-maximal inhibitory concentration: 2.37 ug/mL
Estimate against measurement, compound 4: 2.0-fold (0.30 log units) below, within the range that was stated.
By their numbers in this assay, from the lowest: compound 2; then compound 1; then compounds 4 and 3 (each within the scatter of the next).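

Going from fluoro to bromo on this aromatic carbon gives a 6.8-fold higher number from compound 2 to compound 4 (0.83 log units; beyond the scatter) in this assay, the largest of the halogen swaps at this place. Going from chloro to bromo at the same carbon also raises the number, with a 2.6-fold higher number from compound 1 to compound 4 (0.41 log units; beyond the scatter), so the earlier single swap now extends to a series of three: fluoro gives the lowest number, chloro the middle one and bromo the highest, with every step beyond the scatter and no compound in the series going against that order. Nothing available here explains why the number rises along this series, so the order stands as an observation only.

The three halogen compounds cannot show whether iodo at this place would continue the rise, or whether the order depends on the halogens alone, since a hydrogen, a methyl, a methoxy or an amine on the same carbon would be needed for that comparison. From the compounds shown here alone, whether fluoro keeps its lead when the rest of the shared core changes also stays open, as compound 3 differs from compound 2 in more than one place.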